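The source may report more compounds than this note shows. Statements on the series, on what has been measured and on what is new or still open speak of the compounds shown alone.

Compound 1, `CCCCCCCON1C(=O)[C@@H](NC(=O)OCCCCC2CCCCC2)[C@@H]1C`: 2230 nM
Compound 2, `CC(=O)CCCON1C(=O)[C@@H](NC(=O)OCCCCC2CCCCC2)[C@@H]1C`: 75 nM

Going by the values given here, in an assay on HEK293 cells for inhibition of N-acylethanolamine-hydrolyzing acid amidase (Homo sapiens), read by fluorescence, with stated times of 10 min and 50 min (a lower number here means a stronger inhibitor, a higher number a weaker inhibitor), compound 2 holds the lower of the two numbers, and the only measured step, a 30-fold lower number from compound 1 to compound 2 (1.47 log units; beyond the scatter), separates it from compound 1. Compound 3, `C[C@H]1[C@H](NC(=O)OCCCCC2CCCCC2)C(=O)N1OCCCCc1ccccc1`, is not yet measured. It differs from compound 2 by benzyl in place of acetyl on a saturated chain carbon, three bonds along the chain from an oxygen on an unsaturated carbon. Among the compounds with values here, the step of a 30-fold lower number from compound 1 to compound 2 (1.47 log units; beyond the scatter) is the one comparison that bears on this change: there the acetyl replaced butyl and the number fell sharply, and in compound 3 the acetyl is taken away again. A higher number is therefore expected, though a benzyl end has no precedent among these compounds. Compound 3 is estimated at 1000 nM, between 250 nM and 4000 nM, which means an expected step of a 13-fold higher number from compound 2 to compound 3 (1.12 log units; beyond the scatter).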

Compound 3, half-maximal inhibitory concentration: 1240 nM
Beside the measured number, compound 3's estimate is 1.2-fold (0.09 log units) below it; the measured number falls inside the stated range.
By their numbers in this assay, from the lowest: compound 2; then compounds 3 and 1 (each within the scatter of the next).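

In this assay, replacing the acetyl end with an aromatic one does not keep the low number of compound 2: the change to 4-phenylbutyl gives a 17-fold higher number from compound 2 to compound 3 (1.22 log units; beyond the scatter) and is a large loss. The comparison with the chain of compound 1, a 1.8-fold lower number from compound 1 to compound 3 (0.25 log units; within the scatter), lies within the scatter, so among these three compounds only the 3-acetylpropyl end stands apart. From the compounds shown here alone, it remains open whether an alcohol, an amine or a carboxylic acid at the chain end would serve as the acetyl does, and how a longer chain carrying the acetyl would read. No measured evidence accounts for these differences.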